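Piperazine substituent change from cyclohexyl to an amide-bearing chain

The source may report more compounds than this note shows. Statements on the series, on what has been measured and on what is new or still open speak of the compounds shown alone.

The series rests on a shared core, seen first in compound 1 `Cn1c(-c2ccc(Cl)cc2)c(CCC(=O)N2CCN(CC3CCCCC3)CC2)c2cc(Cl)ccc21` and kept in compound 2 `Cn1c(-c2ccc(Cl)cc2)c(CCC(=O)N2CCN(C3CCCCC3)CC2)c2cc(Cl)ccc21`. In an assay on CHO cells with Substance-P receptor (Homo sapiens) as the target (on this read-out lower numbers stand for stronger inhibition and higher numbers for weaker inhibition), compound 1 gives 2.9 nM, while compound 2 gives 0.35 nM. Going by the values given here, the one step between them, an 8.3-fold lower number from compound 1 to compound 2 (0.92 log units; beyond the scatter), covers the exchange of cyclohexylmethyl for cyclohexyl on the amine nitrogen in the ring. Within these two numbers compound 2 holds the lowest value, with compound 1 standing above it by a step that lies beyond the scatter.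

Compound 3 `CN(C(=O)CN1CCN(C(=O)CCc2c(-c3ccc(Cl)cc3)n(C)c3ccc(Cl)cc23)CC1)c1ccccc1` has not yet been measured in this assay. Its change from compound 2 is (methyl(phenyl)carbamoyl)methyl in place of cyclohexyl on an amine nitrogen in a ring. Among the compounds with values here, only the step from compound 1 to compound 2 touches the same ring nitrogen, and it altered a carbon-only group by a single atom, whereas here a whole cyclohexyl leaves and a longer chain with an amide enters. That step therefore carries little direct weight, and the expected result for compound 3 is a weaker number, estimated as an 8.6-fold higher number from compound 2 to compound 3 (0.93 log units; beyond the scatter). The estimate for compound 3 is 3 nM, with a range from 0.5 nM to 20 nM.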

Compound 3, half-maximal inhibitory concentration: 0.13 nM
The estimate for compound 3 lay 23-fold (1.36 log units) above the measured number; the whole stated range lies above it.
By their numbers in this assay, from the lowest: compound 3; then compound 2; then compound 1.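

The amine nitrogen in the ring proves to tolerate more than saturated carbon-only groups: in this assay there is a 2.7-fold lower number from compound 2 to compound 3 (0.43 log units; beyond the scatter) when cyclohexyl gives way to (methyl(phenyl)carbamoyl)methyl, a larger group that brings an aromatic ring, a carbonyl and a hydrogen-bond acceptor. The comparison with the cyclohexylmethyl compound keeps the saturated chain carbon bound to that nitrogen and changes only what this carbon carries, methyl(phenyl)carbamoyl in place of cyclohexyl, and it gives a 22-fold lower number from compound 1 to compound 3 (1.35 log units; beyond the scatter), the largest step among these three compounds. Nothing in the available data accounts for either step.

The compounds shown leave open which part of the new group goes with the lower number, as the carbonyl, the methyl on the amide nitrogen and the phenyl all enter together in a single change. They also leave open how the number would respond to a secondary amide with the amide hydrogen in place of that methyl, to a pyridine ring in place of the phenyl, or to a longer chain carrying the same amide.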